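The compounds below may be only part of what the source reports. "The series", "measured", "known", "first", "only" and "open" are said of these compounds alone.

Measured so far in a functional assay on the whole organism (strain Wister albino) for inhibition, with Rattus norvegicus as the target, read by paw edema, with stated times of 1 h and 4 h, at a dose of 50 mg/kg by the intraperitoneal route; a higher number here means more inhibition at the dose given (going by the name of the read-out), a lower number less inhibition:
compound 1, `CCOC(=O)c1c(-c2ccc(Cl)cc2)cc(-c2ccccc2)nc1N1CCCCC1`, compound 1 gives 70.1%
compound 2, `CCOC(=O)c1c(-c2ccc(Cl)cc2)cc(-c2ccccc2)nc1Nc1ccccc1`, compound 2 gives 83.8%
compound 3, `CCOC(=O)c1c(-c2ccc(Cl)cc2)cc(-c2ccccc2)nc1Nc1ccc(C)cc1`, compound 3 gives 61.8%

Compound 3 has the lowest of the three numbers. Its nearest neighbour is compound 1, and that gap is within the scatter, so the two cannot be ordered; the gap to compound 2 is beyond the scatter, and the measured step of a number 22 percentage points lower from compound 2 to compound 3 (beyond the scatter) describes it.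

Compound 4, `CCOC(=O)c1c(-c2ccc(Cl)cc2)cc(-c2ccccc2)nc1Nc1ccc(OC)cc1`, is not yet measured. It differs from compound 3 in one place: methoxy in place of methyl on an aromatic carbon.

Going by the values given here, no measured step changes methyl to methoxy, so no step bears directly on this change. The nearest thing the data offer is a number 22 percentage points lower from compound 2 to compound 3 (beyond the scatter), where a group was put onto the anilino ring, and a number 13.7 percentage points higher from compound 1 to compound 2 (beyond the scatter), where the anilino group itself replaced piperidin-1-yl. Neither tells what a methoxy does in place of a methyl. An account for compound 4 therefore rests mainly on compound 3 itself, and the expected step of a number 3.2 percentage points higher from compound 3 to compound 4 (within the scatter) is no larger than the scatter, with a wide range in either direction.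

Compound 4 is estimated at 65% in this assay, between 48% and 82%.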

Compound 4, a percentage reported as inhibition, in the whole organism at one dose (the size of the read-out at that dose, not a potency): 38.9%
Beside the measured number, compound 4's estimate is 26.1 percentage points above it; the measured number lies below the stated range.
By their numbers in this assay, from the lowest: compound 4; then compounds 3 and 1 (each within the scatter of the next); then compound 2.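

In this assay, methyl and methoxy prove not to be interchangeable on the aromatic carbon para to a large group: exchanging one for the other gives a number 22.9 percentage points lower from compound 3 to compound 4 (beyond the scatter). Methoxy in place of hydrogen at this position gives a number 44.9 percentage points lower from compound 2 to compound 4 (beyond the scatter), so with a number 22 percentage points lower from compound 2 to compound 3 (beyond the scatter) already on record, both groups placed here lower the number, and the fall is not confined to methyl. The (4-methoxyphenyl)amino group also gives a number 31.2 percentage points lower from compound 1 to compound 4 (beyond the scatter), which shows that an arylamino group can clearly fall short of piperidin-1-yl, something the methyl compound, within the scatter of that piperidine compound, could not show; nothing measured here offers a reason for these differences.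

The compounds shown leave open whether the number falls in the same way with a fluorine, a hydroxyl or a dimethylamino group on this carbon. They also leave open whether these steps would hold if the ethyl ester on the core were a carboxylic acid or an amide.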